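A Ring Swap on the Lowest Compound

The compounds below may be only part of what the source reports. "The series", "measured", "known", "first", "only" and "open" are said of these compounds alone.

In a functional assay on MV4-11 cells (Homo sapiens) for inhibition, read by luminescence, with a stated time of 72 h, tested at 5 uM (a higher number here means more inhibition of growth at the concentration tested, a lower number less inhibition of growth), compound 1 `C=CS(=O)(=O)NC/C=C/c1cc(OC)cc(O)c1C(=O)OCC1CCCCC1` gives 56.4% as the lowest of three measured numbers. Compound 2 `COc1cc(O)c(C(=O)OCC(C)c2ccccc2)c(/C=C/CN2C(=O)C=CC2=O)c1` reaches 99% and compound 3 `COc1cc(O)c(C(=O)OC(C)C)c(/C=C/CN2C(=O)C=CC2=O)c1` reaches 99.8% and so both stand well above it. Compound 4 `C=CS(=O)(=O)NC/C=C/c1cc(OC)cc(O)c1C(=O)OCc1ccc(F)cc1` has not been measured yet, and it keeps the core of compound 1. The change 4-fluorophenyl in place of cyclohexyl on a saturated chain carbon bound to an oxygen next to a carbonyl group swaps a non-aromatic ring for an aromatic one, both six-membered, on a saturated chain carbon bound to an oxygen next to a carbonyl group. Within the data shown here, only one measured step bears on this, a number 0.8 percentage points higher from compound 2 to compound 3 (within the scatter) with isopropyl in place of 2-phenylpropyl on an oxygen next to a carbonyl group. That guide is weak. Compounds 2 and 3 also differ from compound 1 elsewhere in the structure, and both sit near the top of the scale. The estimated step is a number 1.6 percentage points higher from compound 1 to compound 4 (within the scatter) with no firm direction expected. Compound 4 is expected at 58% with an estimated range from 38% to 80% for now.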

Compound 4, percent growth inhibition at one concentration: 70.5%
Compound 4: middle estimate off by 12.5 percentage points, on the low side, within the range that was stated.
By their numbers in this assay, from the lowest: compound 1; then compound 4; then compounds 2 and 3 (each within the scatter of the next).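

The group on a saturated chain carbon bound to an oxygen next to a carbonyl group matters on the core of compound 1: in this assay, 4-fluorophenyl in place of cyclohexyl gives a number 14.1 percentage points higher from compound 1 to compound 4 (beyond the scatter). This modest step lies beyond the scatter, so this place responds to a swap between two six-membered rings, at least for this pair. Nothing available here explains the rise.

The swap makes the ring aromatic and adds a fluorine at once, so the compounds shown cannot separate those two changes; a plain phenyl ring without the fluorine would be needed to do that. On these data alone, it also remains open how a longer chain or an amine at this place would read out on the same core.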